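The source may hold more compounds than are shown below. What is called first, only, known or untested is meant among the compounds shown, and "the series" means these compounds.

Compound 2 `CCCCNc1nc(N)nc(C)c1F` stands at the high end of the two numbers recorded so far: in an assay on HEK293 cells for agonist activity at Toll-like receptor 8 (Homo sapiens), read by reporter gene assay (on this read-out lower numbers stand for an effect already at smaller amounts and higher numbers for an effect only at larger amounts of compound), compound 2 gives 34000 nM. Its nearest neighbour is compound 1 `CCCCNc1nc(N)nc(C)c1Br`, which differs only in the halogen on the aromatic carbon, and in this assay compound 1 gives 8500 nM. Among the measured compounds shown here, the single measured step, a 4.0-fold higher number from compound 1 to compound 2 (0.60 log units; beyond the scatter), therefore shows that swapping the larger halogen for the smaller one costs activity by a modest but real margin.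

Compound 3 `CCCCNc1cc(C)nc(N)n1` has not been measured. It carries hydrogen in place of fluoro on an aromatic carbon, so the halogen is removed altogether. For the measured compounds named here, only that one step bears on this change, and it points the same way: going from bromo to fluoro already weakened the compound, and taking the halogen away entirely is expected to continue the trend rather than reverse it, though nothing in the data fixes how far. For compound 3 the expected step in this assay is a 1.8-fold higher number from compound 2 to compound 3 (0.25 log units; within the scatter), a modest shift toward higher numbers. Compound 3 is therefore estimated at 60000 nM, with a range from 20000 nM to 180000 nM.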

Compound 3, half-maximal effective concentration: 22000 nM
Compound 3: middle estimate off by 2.7-fold (0.44 log units), on the high side, within the range that was stated.
By their numbers in this assay, from the lowest: compound 1; then compounds 3 and 2 (each within the scatter of the next).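

In this assay, the new result shows that hydrogen and fluoro on this aromatic carbon cannot be told apart, since the step is a 1.5-fold lower number from compound 2 to compound 3 (0.19 log units; within the scatter), so the earlier idea of activity falling away steadily as the halogen shrinks and then disappears does not hold. Bromo is the only one of the three groups that separates from the others at this position: removing it altogether gives a 2.6-fold higher number from compound 1 to compound 3 (0.41 log units; beyond the scatter), a modest step but a real one, so bromo does better here than bare hydrogen, while fluoro offers no measurable advantage over hydrogen. The data supplied offer no measured explanation for why bromo stands apart from the other two groups.

On these data alone, it remains open whether this gain belongs to bromo alone or would also appear with chloro, iodo, a nitrile or trifluoromethyl on the same carbon. As far as these compounds go, it is also open whether bromo would keep its edge over hydrogen if the group of 5 heavy atoms on the neighbouring ring position gave way to a longer chain.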